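A few compounds are considered here, and "the series" means these few. Any claim that something is new, unique, unknown or untested is made for them only; others in the source may bear on it.

Three compounds share one core and differ only in the group on the carbonyl carbon. Compound 1 `CC(Cl)CC(=O)NC1=C(C#N)C(c2ccc(Cl)cc2Cl)C2=C(CCCC2=O)N1c1ccc(S(N)(=O)=O)cc1` gives 20% in a functional assay on Ehrlich cells (Mus musculus) for cytotoxicity, read by trypan blue exclusion, with a stated time of 2 h, tested at 10 ug/mL; a higher number here means a stronger effect of the compound at the concentration tested, a lower number a weaker effect. Compound 2 `N#CC1=C(NC(=O)C2CC2)N(c2ccc(S(N)(=O)=O)cc2)C2=C(C(=O)CCC2)C1c1ccc(Cl)cc1Cl` gives 20% in this assay, and the step of no change at the digits printed from compound 1 to compound 2 (within the scatter) shows the two numbers as indistinguishable. Compound 3 `N#CC1=C(NC(=O)c2ccccc2)N(c2ccc(S(N)(=O)=O)cc2)C2=C(C(=O)CCC2)C1c1ccc(Cl)cc1Cl` gives 50%, the highest of the three numbers; the steps of a number 30 percentage points higher from compound 1 to compound 3 (beyond the scatter) and a number 30 percentage points higher from compound 2 to compound 3 (beyond the scatter) both lie beyond the scatter, so compound 3 stands clearly above compound 1 and compound 2.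

Compound 4 `Cc1ccc(C(=O)NC2=C(C#N)C(c3ccc(Cl)cc3Cl)C3=C(CCCC3=O)N2c2ccc(S(N)(=O)=O)cc2)cc1` is not yet measured. It differs from compound 3 by a single change: methyl in place of hydrogen on an aromatic carbon. Within the data shown here, none of the measured steps touches this place. Each of them exchanged the whole group on the carbonyl carbon, and the two that brought in the phenyl gave a modest rise, while the one between the two non-aromatic groups gave none. A methyl added to that phenyl is a smaller alteration than any that was measured, so no step beyond the scatter is expected. Compound 4 is expected to give about 50% in this assay, with a likely range from 30% to 70%. The step of no change at the digits printed from compound 3 to compound 4 (within the scatter) is what this estimate implies.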

Compound 4, a percentage reported as activity, at one concentration (the size of the read-out at that concentration, not a potency): 20%
Beside the measured number, compound 4's estimate is 30 percentage points above it, outside the stated range (below it).
By their numbers in this assay, from the lowest: compounds 1, 2 and 4 (each within the scatter of the next); then compound 3.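

In this assay, among these compounds, the addition of one methyl to the phenyl group, para to a large group, gives a number 30 percentage points lower from compound 3 to compound 4 (beyond the scatter), so this aromatic carbon responds to a change of a single heavy atom, something the earlier steps could not show because each exchanged the whole group on the carbonyl carbon. The rise seen with phenyl also does not extend to 4-methylphenyl: the steps of no change at the digits printed from compound 2 to compound 4 (within the scatter) and no change at the digits printed from compound 1 to compound 4 (within the scatter) put compound 4 level with the two compounds that carry non-aromatic groups, so compound 4 goes against any reading that an aromatic group on the carbonyl carbon is enough for the higher number. Nothing in the data shown accounts for this step.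

The compounds shown leave open whether the loss is particular to methyl or would also follow from another group in the same place, such as a chlorine, a methoxy group or a hydroxyl group. They also leave open whether a methyl on another carbon of the same ring would give the same result.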